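Methyl in place of bromo on an aromatic carbon

The compounds below may be only part of what the source reports. "The series", "measured", "known", "first", "only" and "open" are said of these compounds alone.

In a functional assay on HCT-116 cells (Homo sapiens) for inhibition, read by CCK-8 assay, with a stated time of 48 h (on this read-out higher numbers stand for weaker inhibition and lower numbers for stronger inhibition), compound 1 `COc1ccc(CN(C(=O)CSC(=S)N2CCN(C(=O)OC(C)(C)C)CC2)c2cc(OC)c(OC)c(OC)c2)cc1` gives 620 nM, compound 2 `COc1cc(N(Cc2ccc(Cl)cc2)C(=O)CSC(=S)N2CCN(C(=O)OC(C)(C)C)CC2)cc(OC)c1OC` gives 8490 nM, and compound 3 `COc1cc(N(Cc2ccc(Br)cc2)C(=O)CSC(=S)N2CCN(C(=O)OC(C)(C)C)CC2)cc(OC)c1OC` gives 11400 nM. Compound 3 therefore sits level with compound 2 at the high end of these numbers, and both lie far from compound 1.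

The next compound, compound 4 `COc1cc(N(Cc2ccc(C)cc2)C(=O)CSC(=S)N2CCN(C(=O)OC(C)(C)C)CC2)cc(OC)c1OC`, differs from compound 3 in one place: methyl in place of bromo on an aromatic carbon. This puts methyl in place of bromo on an aromatic carbon, para to a large group.

Among the measured compounds shown here, three measured steps bear on this change. Replacing methoxy with chloro gave a 14-fold higher number from compound 1 to compound 2 (1.14 log units; beyond the scatter), a large step, and replacing methoxy with bromo gave an 18-fold higher number from compound 1 to compound 3 (1.26 log units; beyond the scatter), also large. Exchanging one halogen for the other gave only a 1.3-fold higher number from compound 2 to compound 3 (0.13 log units; within the scatter). The two halogens thus cannot be told apart here, while the methoxy compound stands well apart from them. For the measured compounds named here, no methyl compound has been measured, so its place along that wide gap is uncertain. A moderate move away from the halogen level, towards a lower number, seems the likeliest outcome.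

The expected change is a 2.9-fold lower number from compound 3 to compound 4 (0.45 log units; beyond the scatter). Compound 4 is estimated at 4000 nM, with an expected range from 900 nM to 13000 nM.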

Compound 4, half-maximal inhibitory concentration: > 20000 nM
Compound 4 was reported as a limit (the forecaster's own chance of this, stated with the estimate: 3%); middle value at least 5.0-fold (0.69 log units) from the limit.
By their numbers in this assay, from the lowest: compound 1; then compounds 2 and 3 (each within the scatter of the next). At a limit, above all of these: compound 4.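

Compound 4 carries only a limit in this assay, not a number: the limit of > 20000 nM in this assay, at which 1 of the 4 values shown sits. Set against the halogen compounds, this gives an at least 1.7-fold higher number from compound 3 to compound 4 (0.24 log units; that floor lies within the scatter) and an at least 2.3-fold higher number from compound 2 to compound 4 (0.37 log units; beyond the scatter); the first floor cannot separate compound 4 from compound 3, while the second shows that compound 4 stands apart from compound 2, on the side away from compound 1. With an at least 32-fold higher number from compound 1 to compound 4 (1.50 log units; beyond the scatter), the result shows that the large gap seen earlier is not confined to the halogens: methyl, a group without a halogen, also fails to bring this position near compound 1, so among the four compounds only the methoxy compound reaches the low end of the read-out.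

As far as these compounds go, how far compound 4 lies beyond its limit stays open, and so does the true size of each of its steps. Also open, from the compounds shown here alone, is what an ethoxy, a hydroxyl or a dimethylamino group would give on this aromatic carbon, which would show whether the result of compound 1 is particular to methoxy or is shared by other groups bearing oxygen or nitrogen.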